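The source may report more compounds than this note shows. Statements on the series, on what has been measured and on what is new or still open speak of the compounds shown alone.

In a functional assay on SMMC-7721 cells (Homo sapiens) for inhibition, read by CCK-8 assay, with a stated time of 72 h, tested at 8 uM (on this read-out higher numbers stand for more inhibition of growth at the one concentration tested and lower numbers for less inhibition of growth), compound 2 `COc1ccc(SCc2ccc(C(=O)Nc3ccccc3N)cc2)cc1` gives 80.1%, and compound 3 `COc1ccc(SCc2ccc(C(=O)Nc3ccccc3N)cc2)cc1OC` gives 78.9%, within the scatter of it. Compound 1 `Nc1ccccc1NC(=O)/C=C/c1ccc(CSc2cccc(F)c2)cc1` lies far lower at 8.25%. Next comes compound 4 `Nc1ccccc1NC(=O)c1ccc(CSc2ccc(Cl)cc2)cc1`, with this difference: chloro in place of methoxy on an aromatic carbon. This is chloro in place of methoxy on an aromatic carbon, para to a large group. Within the data shown here, the one measured step bearing on it is a number 1.2 percentage points lower from compound 2 to compound 3 (within the scatter), which is methoxy in place of hydrogen on an aromatic carbon. Among the measured compounds shown here, that step keeps the original methoxy, so it is only a loose guide, and no chloro compound has been measured. No step beyond the scatter is therefore expected in this assay. The estimated step is a number 5.1 percentage points lower from compound 2 to compound 4 (within the scatter). For compound 4 the estimate is 75%, with an expected range of 55% to 90%.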

Compound 4, percent growth inhibition at one concentration: 16.5%
For compound 4 the middle estimate is 58.5 percentage points above the measured one; the measured number lies below the stated range.
By their numbers in this assay, from the lowest: compounds 1 and 4 (each within the scatter of the next); then compounds 3 and 2 (each within the scatter of the next).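

The change from 4-methoxyphenyl to 4-chlorophenyl in this assay gives a number 63.6 percentage points lower from compound 2 to compound 4 (beyond the scatter) and shows that this position, para to a large group, is sensitive to its substituent. Compound 3 retained this methoxy, so its value showed nothing about replacing the group. No available measurement explains the loss.

Going by these compounds, whether the oxygen, the methyl or the whole methoxy matters remains open. So does whether a hydroxyl, an amine or an ethoxy at this position would restore growth inhibition.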